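The source may report more compounds than this note shows. Statements on the series, on what has been measured and on what is new or still open speak of the compounds shown alone.

Compound 1 `CCCOc1cc(=O)oc2cc(OCc3ccccc3)ccc12`: 575 nM
Compound 2 `COCOc1cc(=O)oc2cc(OCc3cccc(Cl)c3)ccc12`: 100 nM

Among the two measured compounds, compound 2 gives the lowest number in an assay on isolated protein (strain Sprague-Dawley) for inhibition of Amine oxidase [flavin-containing] B (Rattus norvegicus), read by spectrophotometry, with a stated time of 5 min (on this read-out lower numbers stand for stronger inhibition and higher numbers for weaker inhibition), and the nearest measured neighbour, compound 1, sits a good deal higher, beyond the scatter. Compound 3 `O=c1cc(Cl)c2ccc(OCc3cccc(Cl)c3)cc2o1` has not been measured; the change is chloro in place of methoxymethoxy on an aromatic carbon. Going by the values given here, no measured pair shows this chloro in place of methoxymethoxy, so the direction rests on no observed step. The step from compound 2 to compound 3 is expected to be small, a 1.7-fold lower number from compound 2 to compound 3 (0.22 log units; within the scatter), with compound 3 estimated at 60 nM, in a range from 15 nM to 250 nM.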

Compound 3, half-maximal inhibitory concentration: 20.9 nM
The estimate for compound 3 lay 2.9-fold (0.46 log units) above the measured number; the range from low to high includes it.
By their numbers in this assay, from the lowest: compound 3; then compound 2; then compound 1.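

In this assay, chloro in place of methoxymethoxy on this aromatic carbon, opposite the ring oxygen, gives a 4.8-fold lower number from compound 2 to compound 3 (0.68 log units; beyond the scatter) and so lies beyond the scatter. The position therefore does not need methoxymethoxy and its two hydrogen-bond acceptors for a low number, since a single chlorine atom with no acceptors goes lower. Nothing shown explains this step. On these data alone, what an amine, a carboxylic acid or a longer chain on this carbon would give stays open. So does whether the same step holds when the rest of the core differs.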